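From Bromo to Methyl on a Shared Core

The compounds below may be only part of what the source reports. "The series", "measured", "known", "first", "only" and "open" are said of these compounds alone.

In a functional assay on PC-3 cells (Homo sapiens) for antiproliferative activity, read by sulforhodamine B assay, with a stated time of 48 h (on this read-out lower numbers stand for stronger inhibition and higher numbers for weaker inhibition), compound 1 `CO/N=C1/C(=O)N(CCCCCCC(=O)NO)c2ccccc21` gives 1670 nM and compound 2 `CO/N=C1/C(=O)N(CCCCCCC(=O)NO)c2ccc(Br)cc21` gives 8910 nM. Compound 2 therefore holds the higher of the two numbers, making it the weaker inhibitor of this pair. The next compound, compound 3 `CO/N=C1/C(=O)N(CCCCCCC(=O)NO)c2ccc(C)cc21`, carries methyl in place of bromo on an aromatic carbon.

Among the measured compounds shown here, only one measured step bears on this change: a 5.3-fold higher number from compound 1 to compound 2 (0.73 log units; beyond the scatter). This modest step, beyond the scatter, came from bromo in place of hydrogen at the same carbon. For the measured compounds named here, no measured compound carries a methyl, so the evidence is thin. The removal of the bromo is still expected to bring back part of that step, moving the number toward the 1670 nM of compound 1 without necessarily reaching it. In this assay, the expected change is small and points toward a lower number: a 2.2-fold lower number from compound 2 to compound 3 (0.35 log units; beyond the scatter). For compound 3, the estimated value is 4000 nM, with an expected range from 1400 nM to 11000 nM.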

Compound 3, half-maximal inhibitory concentration: 350 nM
Estimate against measurement, compound 3: 11-fold (1.06 log units) above; measured number below the stated range.
By their numbers in this assay, from the lowest: compound 3; then compound 1; then compound 2.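

In this assay the step of a 25-fold lower number from compound 2 to compound 3 (1.41 log units; beyond the scatter) is large, so this aromatic carbon, meta to a fused ring and para to a fused ring, is highly sensitive to which group it carries, even when one single heavy atom simply replaces another. Among the compounds shown here, the earlier compounds showed only that bromo raises the number, which could have meant that any added group at this carbon costs activity, but the step of a 4.8-fold lower number from compound 1 to compound 3 (0.68 log units; beyond the scatter) runs the other way and makes compound 3 the strongest inhibitor of the three. Nothing measured here explains why bromo and methyl, at the same carbon and each with one heavy atom, move the number in opposite directions.

With only hydrogen, bromo and methyl at this carbon, the compounds shown cannot tell whether methyl is a special case or one point in a wider trend, and chloro, ethyl, methoxy or an amine on the same shared core would begin to settle that. They also leave open whether the gain from methyl would hold if the chain on the ring nitrogen were shorter or longer.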